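Does one more ring methyl change cytotoxicity?

The source may report more compounds than this note shows. Statements on the series, on what has been measured and on what is new or still open speak of the compounds shown alone.

Values in an ADME assay on MDBK cells (Bos taurus) for cytotoxicity, read by MTT assay; on this read-out lower numbers stand for higher toxicity in this test and higher numbers for lower toxicity in this test:
- Compound 1 `CCC1CCC(OCCCCCCN2C[C@H](O)[C@@H](O)[C@H](O)[C@H]2CO)CC1`: > 500000 nM, a limit
- Compound 2 `OC[C@@H]1[C@@H](O)[C@H](O)[C@@H](O)CN1CCCCCCOc1cc(Cl)ccc1Cl`: 320000 nM
- Compound 3 `CC1CCC(OCCCCCCN2C[C@H](O)[C@@H](O)[C@H](O)[C@H]2CO)CC1C`: > 500000 nM, a limit

Compound 3 stands at the limit of > 500000 nM in this assay, at which 2 of the 3 values shown sit, and compound 1 shares that limit. Only compound 2, at 320000 nM, has a true number.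

Compound 4 `CC1CC(OCCCCCCN2C[C@H](O)[C@@H](O)[C@H](O)[C@H]2CO)CC(C)(C)C1` makes one change to compound 3: a group of 9 heavy atoms (9 carbon; one six-membered non-aromatic ring of carbon only) in place of a group of 8 heavy atoms (8 carbon; one six-membered non-aromatic ring of carbon only), on an oxygen on a saturated carbon. The group that enters is 3,3,5-trimethylcyclohexyl, which again holds one six-membered non-aromatic ring of carbon only.

The closest measured swap, also between two such rings, is a step that the two limits leave unreadable from compound 1 to compound 3, so it gives no size to work from. The two swaps involving the 2,5-dichlorophenyl group of compound 2 are an at least 1.5-fold lower number from compound 1 to compound 2 (0.19 log units; that floor lies within the scatter) and an at least 1.5-fold higher number from compound 2 to compound 3 (0.19 log units; that floor lies within the scatter), and both floors lie within the scatter. For the measured compounds named here, none of these steps shows a change beyond the scatter, so no step of that kind is expected in this assay, in either direction, and another limit would be no surprise. The expected change is a number no higher from compound 3 to compound 4 (the limit leaves the size open). For compound 4 the estimate is 500000 nM, with an expected range of 250000 nM to 700000 nM.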

Compound 4, half-maximal cytotoxic concentration: 250000 nM
Beside the measured number, compound 4's estimate is 2.0-fold (0.30 log units) above it; the measured number falls inside the stated range.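

In this assay, compound 4 is the first compound shown with a non-aromatic carbon ring on the oxygen to give a true number rather than a limit. Measured against the two other compounds of that kind, it gives an at least 2.0-fold lower number from compound 3 to compound 4 (0.30 log units; that floor lies within the scatter) and an at least 2.0-fold lower number from compound 1 to compound 4 (0.30 log units; that floor lies within the scatter), so these steps now have a floor, but neither floor shows a change beyond the scatter. The comparison with the aromatic group gives a 1.3-fold lower number from compound 2 to compound 4 (0.11 log units; within the scatter), so in this test 3,3,5-trimethylcyclohexyl and 2,5-dichlorophenyl cannot be told apart, and an aromatic ring is not needed for a value of this size.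

Going by these compounds, the step between compound 1 and compound 3 cannot be read, and how far either one truly lies from compound 4 stays open, because both sit at a limit of the assay: the limit of > 500000 nM in this assay, at which 2 of the 4 values shown sit. Also open is how the value would respond to an amine or a carboxylic acid on the ring, or to a longer chain.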